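Pyrazoline series: acylation of the ring nitrogen in compound 2

The compounds below may be only part of what the source reports. "The series", "measured", "known", "first", "only" and "open" are said of these compounds alone.

Measured so far:
compound 1, `CN1CCN(c2ccc(C3=NNC(c4ccc(N(C)C)cc4)C3)cc2)CC1`, 11.4%
compound 2, `CN(C)c1ccc(C2CC(c3ccc(-n4ccnc4)cc3)=NN2)cc1`, 7.6%
compound 3, `CN1CCN(c2ccc(C3=NN(S(=O)(=O)c4ccc(OC(F)(F)F)cc4)C(c4ccc(N(C)C)cc4)C3)cc2)CC1`, 10.6%

All three were run in a functional assay on MDA-MB-231 cells (Homo sapiens) for inhibition, read by sulforhodamine B assay, tested at 10 uM; on this read-out higher numbers stand for more inhibition at the one concentration tested (going by the name of the read-out) and lower numbers for less inhibition. Compound 2 gives 7.6%; compound 3 gives 10.6% and compound 1 gives 11.4%, so the three numbers lie within the usual scatter of one another and no ordering among them is claimed.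

The unmeasured compound 4, `CN(C)c1ccc(C2CC(c3ccc(-n4ccnc4)cc3)=NN2C(=O)c2cc(Cl)cc(Cl)c2)cc1`, differs from compound 2 by (3,5-dichlorophenyl)carbonyl in place of hydrogen on an amine nitrogen in a ring. Among the measured compounds shown here, the only step that has a counted difference, a number 3.8 percentage points lower from compound 1 to compound 2 (within the scatter), concerns a different site and does not inform this change. For the measured compounds named here, compound 3 carries a sulfonyl on the same ring nitrogen where compound 1 carries hydrogen; the pair shows only that compound 1 gives 11.4% and compound 3 gives 10.6%, a gap within the scatter. On this basis no step beyond the scatter is expected from a number 2.4 percentage points higher from compound 2 to compound 4 (within the scatter). Compound 4 is therefore estimated at 10%, with a range from 0% to 25%.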

Compound 4, a percentage reported as inhibition, at one concentration (the size of the read-out at that concentration, not a potency): 48.8%
Estimate against measurement, compound 4: 38.8 percentage points below; measured number outside the range, above it.
By their numbers in this assay, from the lowest: compounds 2, 3 and 1 (each within the scatter of the next); then compound 4.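

In this assay, among the compounds shown here, the amine nitrogen in the ring proves to be a site where a substituent can move the read-out: (3,5-dichlorophenyl)carbonyl in place of hydrogen gives a number 41.2 percentage points higher from compound 2 to compound 4 (beyond the scatter) and this is the only step beyond the scatter. Substitution at this nitrogen does not always do so, as compound 1 gives 11.4% and its sulfonyl counterpart compound 3 gives 10.6% with the two within the scatter, so the pattern rests on this single pair. No available data bear on why the step is this large.

As far as these compounds go, it remains open whether the step needs the two chlorine atoms, since a plain benzoyl or an acetyl group at the same nitrogen would separate them from the carbonyl. From the compounds shown here alone, it is equally open whether (3,5-dichlorophenyl)carbonyl behaves alike with 4-methylpiperazin-1-yl in place of 1H-imidazol-1-yl.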